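Notes on the amide-nitrogen aryl group in this series

The source may hold more compounds than are shown below. What is called first, only, known or untested is meant among the compounds shown, and "the series" means these compounds.

Three compounds on a shared core have been run in a functional assay on A549 cells (Homo sapiens) for antiproliferative activity, read by MTT assay, with a stated time of 72 h; a higher number here means a weaker inhibitor, a lower number a stronger inhibitor. Compound 1 `CN1CCN(Cc2ccc(NC(=O)Nc3ccc4ncnc(Nc5cccc(C(F)(F)F)c5)c4c3)cc2)CC1` gives 1650 nM. Compound 2 `O=C(Nc1ccc(CN2CCCC2)cc1)Nc1ccc2ncnc(Nc3cccc(C(F)(F)F)c3)c2c1` gives 830 nM, and compound 3 `O=C(Nc1cccc(CN2CCCC2)c1)Nc1ccc2ncnc(Nc3cccc(C(F)(F)F)c3)c2c1` gives 860 nM. The two single-point steps among them were a 2.0-fold lower number from compound 1 to compound 2 (0.30 log units; within the scatter) and a 1.0-fold higher number from compound 2 to compound 3 (0.02 log units; within the scatter), so the three numbers are all within the scatter of one another, and compound 3 stands second highest of the three without any separation that can be called real.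

Compound 4 `COc1ccc(NC(=O)Nc2ccc3ncnc(Nc4cccc(C(F)(F)F)c4)c3c2)cc1` is not yet measured. Relative to compound 3 the change is 4-methoxyphenyl in place of 3-((pyrrolidin-1-yl)methyl)phenyl on an amide-type nitrogen. Neither measured step covers this change directly: the step from compound 1 to compound 2 swapped one amine on the saturated chain carbon for another, and the step from compound 2 to compound 3 moved that arm around the ring; both left the number essentially unchanged. Going by the values given here, no compound in the set lacks the amine arm altogether, so the effect of removing it is untested. The working expectation is therefore a step of a 1.4-fold higher number from compound 3 to compound 4 (0.14 log units; within the scatter), with no firm direction claimed and a wide range.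

On that basis compound 4 is estimated at 1200 nM in this assay, between 350 nM and 4500 nM.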

Compound 4, half-maximal inhibitory concentration: 9470 nM
Estimate against measurement, compound 4: 7.9-fold (0.90 log units) below; measured number outside the range, above it.
By their numbers in this assay, from the lowest: compounds 2, 3 and 1 (each within the scatter of the next); then compound 4.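

Going by these compounds alone, the position on the amide-type nitrogen is not indifferent to what it carries: 4-methoxyphenyl in place of 3-((pyrrolidin-1-yl)methyl)phenyl gives an 11-fold higher number from compound 3 to compound 4 (1.04 log units; beyond the scatter) in this assay and is the first step to pass beyond the scatter. Methoxy in place of (pyrrolidin-1-yl)methyl on the aromatic carbon gives an 11-fold higher number from compound 2 to compound 4 (1.06 log units; beyond the scatter) and is rated large, while methoxy in place of (4-methylpiperazin-1-yl)methyl gives a 5.7-fold higher number from compound 1 to compound 4 (0.76 log units; beyond the scatter) and is rated modest, so each of the three compounds with an amine arm separates from compound 4, with none going against this, whereas changing the amine or moving the arm around the ring had shown no such separation. Nothing in hand accounts for the loss, as no supporting data bear on it.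

The compounds shown do not separate the loss of the amine arm from the arrival of methoxy, and an unsubstituted phenyl or a hydroxymethyl on the same ring would address that point. Going by these compounds, it also remains open whether the amine nitrogen itself matters, which a morpholine or a carboxylic acid on the saturated chain carbon would test.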